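Furan-2-yl for 2-Chlorophenyl on a Triazolopyrimidine Hydrazone

A few compounds are considered here, and "the series" means these few. Any claim that something is new, unique, unknown or untested is made for them only; others in the source may bear on it.

Compound 1 `CCCSc1nc(N/N=C(\C)c2ccccc2O)c2nnn(Cc3ccccc3Cl)c2n1` was tested in a functional assay on MGC-803 cells (Homo sapiens) for antiproliferative activity, read by MTT assay, with a stated time of 72 h (a higher number here means a weaker inhibitor, a lower number a stronger inhibitor), and gives 35000 nM. Among the numbers reported, this is the highest of the two that are numbers: compound 2 `C/C(=N\Nc1nc(SCc2ccccc2)nc2c1nnn2Cc1ccccc1)c1ccccc1O` gives 850 nM in this assay, a lower number than that of compound 1, and the gap between the two lies beyond the usual scatter. The third member of the set, compound 3 `CCCSc1nc(N/N=C/c2ccccc2)c2nnn(Cc3ccccc3)c2n1`, reaches only a limit of the assay, > 64000 nM, and no number is known for it. This is the limit described in the limit of > 64000 nM in this assay, at which 1 of the 3 values shown sits.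

Compound 4 `CCCSc1nc(N/N=C(\C)c2ccccc2O)c2nnn(Cc3ccco3)c2n1` has not yet been measured. It differs from compound 1 in one place: furan-2-yl in place of 2-chlorophenyl on a saturated chain carbon bound to an aromatic nitrogen. The change sits on a saturated chain carbon bound to an aromatic nitrogen, and the hydroxyphenyl hydrazone and the propylthio group of compound 1 stay as they are. For the measured compounds named here, no pair among the measured compounds differs by this exchange alone, so its effect cannot be read from the data; the nearest comparisons change several groups at once. The step from compound 1 to compound 4 is therefore expected to be small, a 1.2-fold lower number from compound 1 to compound 4 (0.07 log units; within the scatter), with no direction that can be assigned beyond the scatter. Compound 4 is expected to give about 30000 nM, within a range from 8000 nM to 100000 nM in this assay.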

Compound 4, half-maximal inhibitory concentration: 4760 nM
Beside the measured number, compound 4's estimate is 6.3-fold (0.80 log units) above it, outside the stated range (below it).
By their numbers in this assay, from the lowest: compound 2; then compound 4; then compound 1. At a limit, above all of these: compound 3.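

With the hydroxyphenyl hydrazone and the propylthio group left as they are, replacing 2-chlorobenzyl with (furan-2-yl)methyl gives, in this assay, a 7.4-fold lower number from compound 1 to compound 4 (0.87 log units; beyond the scatter). For the compounds shown here, no earlier pair differed by a single exchange, so this is the first direct evidence that the group on a saturated chain carbon bound to an aromatic nitrogen can move the number beyond the scatter, here in favour of the five-membered aromatic ring with 1 hetero atom over the chlorinated six-membered ring, although the step is only modest. Nothing measured here offers a cause for this step.

The compounds shown leave open whether the step follows from the loss of the chlorine, the change in ring size or the presence of the ring oxygen, and a thiophen-2-yl or an unsubstituted phenyl group at this place, with the rest of compound 4 kept, would help to separate these. Also open, as far as these compounds go, is whether a saturated tetrahydrofuran-2-yl ring would keep the step, and whether the exchange would give a similar result with a different group on the sulfur.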